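Cytotoxicity notes: ethyl in place of phenyl

The source may report more compounds than this note shows. Statements on the series, on what has been measured and on what is new or still open speak of the compounds shown alone.

Measured so far in an ADME assay on TERT-RPE1 cells (Homo sapiens) for cytotoxicity, read by resazurin assay, with a stated time of 48 h; on this read-out higher numbers stand for weaker inhibition and lower numbers for stronger inhibition:
- compound 1 `CCOc1ccc(NC(=O)c2c(N)n[nH]c2Nc2ccccc2)cc1`: 67800 nM
- compound 2 `C=CCNc1[nH]nc2nnn(-c3ccc(OCC)cc3)c(=O)c12`: > 100000 nM, a limit of the assay
- compound 3 `CCN/C(SC)=C(/C#N)C(=O)Nc1ccc(OCC)cc1`: > 100000 nM, a limit of the assay

In this assay, among the measured compounds shown here, compound 1 gives 67800 nM, the only actual number among the three compounds. Compound 2 reaches only a limit of the assay at > 100000 nM. Compound 3 likewise reaches only a limit at > 100000 nM. Taken together, (the limit of > 100000 nM in this assay, at which 2 of the 3 values shown sit), and compound 1 sits not far below that limit.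

Compound 4 `CCNc1[nH]nc(N)c1C(=O)Nc1ccc(OCC)cc1` has not yet been measured in this assay. Compared with compound 1 the change is ethyl in place of phenyl on a nitrogen on an aromatic ring. For the measured compounds named here, no measured pair shows this change, so no step size can be read from the data.

Given that compound 1 gives 67800 nM, compound 4 is expected to show weak inhibition as well. Compound 2 and compound 3 each stop at a limit of the assay. The step this expectation implies, a 1.3-fold higher number from compound 1 to compound 4 (0.10 log units; within the scatter), is expected to stay within the usual scatter or to drift towards weaker inhibition. Compound 4 is estimated at 85000 nM in this assay, with a likely range from 35000 nM to 200000 nM.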

Compound 4, half-maximal inhibitory concentration: > 100000 nM
Compound 4 gave a limit, no number; the forecaster's own chance of this, stated with the estimate: 50%; at least 1.1-fold (0.07 log units) between middle value and limit.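

In this assay, among the compounds shown here, anilino to ethylamino, which takes away the phenyl ring and puts ethyl on a nitrogen on an aromatic ring, gives an at least 1.4-fold higher number from compound 1 to compound 4 (0.16 log units; that floor lies within the scatter) as the first step that can be read at this position. That floor lies within the scatter, so the change shows no shift in the read-out, and it shows that stronger inhibition does not appear with ethyl in place of phenyl. Compound 4 gives only a limit of the assay and not a number, which adds to the limits already seen in the series: the limit of > 100000 nM in this assay, at which 3 of the 4 values shown sit.

The true size of the step cannot be read while one side of it is a limit. On these data alone, whether a longer chain, a benzyl group or a carboxylic acid on that nitrogen would give a measurable number remains open.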